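Ester variation on the shared core: approaching compound 4

The source may hold more compounds than are shown below. What is called first, only, known or untested is meant among the compounds shown, and "the series" means these compounds.

compound 1 `C=C1C(=O)O[C@@H]2CC(C)=C([C@@H](C)CCCOC(C)=O)[C@@H](OC(=O)CN3CCCCC3)[C@H]12` — in a functional assay on SGC-7901 cells (Homo sapiens) for cytotoxicity, read by sulforhodamine B assay, with a stated time of 72 h (on this read-out higher numbers stand for weaker inhibition and lower numbers for stronger inhibition), compound 1 gives 11500 nM
compound 2 `C=C1C(=O)O[C@@H]2CC(C)=C([C@@H](C)CCCOC(C)=O)[C@@H](OC(=O)COc3ccc([N+](=O)[O-])cc3[N+](=O)[O-])[C@H]12` — compound 2 gives only a limit, > 100000 nM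
compound 3 `C=C1C(=O)O[C@@H]2CC(C)=C([C@@H](C)CCCOC(C)=O)[C@@H](OC(=O)COc3ccc4c(CC)noc4c3)[C@H]12` — compound 3 gives 21200 nM

Compound 1 has the lowest number of the two numbers shown; its nearest neighbour is compound 3, with a 1.8-fold higher number from compound 1 to compound 3 (0.27 log units; within the scatter). The value of compound 2 is a limit of the assay, (the limit of > 100000 nM in this assay, at which 1 of the 3 values shown sits), and not a number. From compound 2 to compound 3 the change reads an at least 4.7-fold lower number from compound 2 to compound 3 (0.67 log units; beyond the scatter).

Compound 4 `C=C1C(=O)O[C@@H]2CC(C)=C([C@@H](C)CCCOC(C)=O)[C@@H](OC(=O)c3ccccc3F)[C@H]12` differs from compound 1 by 2-fluorophenyl in place of (piperidin-1-yl)methyl on a carbonyl carbon. Among the measured compounds shown here, no measured step swaps the (piperidin-1-yl)methyl for an aromatic group on the carbonyl carbon directly; the nearest guide is the step from compound 1 to compound 3, which stays within the scatter, while the limit of compound 2 warns that an aromatic ester can also fall out of range. A modest rise in the number is therefore expected, a 1.7-fold higher number from compound 1 to compound 4 (0.24 log units; within the scatter), though a result within the scatter would not surprise.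

Compound 4 is estimated at 20000 nM, with a range from 6000 nM to 70000 nM.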

Compound 4, half-maximal inhibitory concentration: 19300 nM
Compound 4: the middle estimate sits 1.0-fold (0.02 log units) above what was measured; low and high end bracket the measured number.
By their numbers in this assay, from the lowest: compounds 1, 4 and 3 (each within the scatter of the next). At a limit, above all of these: compound 2.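

On the carbonyl carbon, 2-fluorophenyl in place of (piperidin-1-yl)methyl gives a 1.7-fold higher number from compound 1 to compound 4 (0.22 log units; within the scatter) in this assay, so the ring nitrogen of the piperidine and its hydrogen-bond acceptor can go without a change beyond the scatter. Compound 4 also shows that an aromatic ring can sit directly on the carbonyl carbon and still give a number, whereas the aromatic groups of compounds 2 and 3 stand further out, on an oxygen on a saturated carbon. Compound 2 remains a limit and not a number: the limit of > 100000 nM in this assay, at which 1 of the 4 values shown sits.

As far as these compounds go, whether the fluorine contributes stays open, since a plain phenyl would be needed to separate it from the ring. Also open, from the compounds shown here alone, is whether a carboxylic acid, an open-chain amine or a longer chain on the carbonyl carbon would move the number beyond the scatter in this assay.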